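Three Indolyl Enones All Beyond the Cytotoxicity Limit

The compounds below may be only part of what the source reports. "The series", "measured", "known", "first", "only" and "open" are said of these compounds alone.

Compound 1 `COc1ccc2[nH]cc(C(=O)/C(C#N)=C/C=C(\Cl)c3ccc(Br)cc3)c2c1` in a functional assay on MCF7 cells (Homo sapiens) for cytotoxicity, read by sulforhodamine B assay, with a stated time of 48 h (a lower number here means that less compound is tolerated, a higher number that more compound is tolerated), gives > 100000 nM, a limit of the assay rather than a number.
Compound 2 `N#C/C(=C\C=C(/Cl)c1ccc(Br)cc1)C(=O)c1c[nH]c2ccccc12` in this assay gives > 100000 nM, likewise only a limit.
Compound 3 `COc1ccc(/C(Cl)=C/C=C(\C#N)C(=O)c2c[nH]c3ccccc23)cc1` in this assay gives > 100000 nM, again a limit.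

All three values sit at the limit of > 100000 nM in this assay, at which 3 of the 3 values shown sit, so the step that the two limits leave unreadable from compound 2 to compound 1, made by methoxy in place of hydrogen on an aromatic carbon, cannot be sized, and the difference between the cores of compound 3 and compound 2, (methoxy in place of bromo on an aromatic carbon), is equally unreadable in a step that the two limits leave unreadable from compound 2 to compound 3. Compound 4 `COc1ccc(/C(Cl)=C/C=C(\C#N)C(=O)c2c[nH]c3ccccc23)cc1OC` carries the same kind of change, (methoxy in place of hydrogen on an aromatic carbon), though here on a six-membered ring of carbon only, ortho to a methoxy group and meta to a large group, not on a fused system. With no readable step on record, compound 4 is expected to stay at the limit, a step that the limit leaves unreadable from compound 3 to compound 4. The estimate for compound 4 is 150000 nM, between 50000 nM and 500000 nM.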

Compound 4, concentration lethal to 50% of the cells: > 100000 nM
Compound 4 ended at the assay's limit (the forecaster's own chance of this, stated with the estimate: 85%); the middle value lies beyond the limit too.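

Among the compounds shown here, compound 3 and compound 4 each end at a limit of the assay rather than a number, so no step between them can be read: the limit of > 100000 nM in this assay, at which 4 of the 4 values shown sit. The compounds shown leave open whether a methoxy change alters cytotoxicity at all.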